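A few compounds are considered here, and "the series" means these few. Any claim that something is new, unique, unknown or untested is made for them only; others in the source may bear on it.

Two compounds of the series carry numbers in a functional assay on CHO cells for agonist activity at metabotropic glutamate receptor 2 (Homo sapiens), read by scintillation counting and GTPgammaS binding, with a stated time of 30 min; a lower number here means a smaller maximal response, a higher number a larger maximal response. Compound 1, `COc1c(C2CCN(c3ccn4c(CC5CC5)nnc4c3Cl)CC2)ccc(F)c1F`, gives 342%. Within the data shown here, compound 2, `COc1ccc(F)c(F)c1C1CCN(c2ccn3c(CC4CC4)nnc3c2Cl)CC1`, gives 258% and stands lowest of the two; the single measured step, a number 84 percentage points lower from compound 1 to compound 2 (beyond the scatter), is what separates them. Compound 3, `COc1cc(F)cc(F)c1C1CCN(c2ccn3c(CC4CC4)nnc3c2Cl)CC1`, has not yet been measured. It differs from compound 2 by 2,4-difluoro-6-methoxyphenyl in place of 2,3-difluoro-6-methoxyphenyl on a saturated ring carbon. Among the measured compounds shown here, the one measured step bears on this only loosely: it too rearranged the fluorine and methoxy substituents on the phenyl ring held by the saturated ring carbon, and the resulting change in maximal response was beyond the scatter. For the measured compounds named here, no measured pair shows the present rearrangement itself, so the direction is open. Given that one such reshuffling of substituents moved the response by a large amount, a step of moderate size in either direction is plausible here, and the range must be wide. For compound 3 the expected maximal response is 230%, within 150% to 320%. The step this estimate implies is a number 28 percentage points lower from compound 2 to compound 3 (beyond the scatter), an expectation resting on that single precedent.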

Compound 3, largest response reached (Emax), in percent of the reference or control that the assay uses: 256%
Compound 3: middle estimate off by 26 percentage points, on the low side, and the stated range covers the measured number.
By their numbers in this assay, from the lowest: compounds 3 and 2 (each within the scatter of the next); then compound 1.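

Working note on the phenyl group held by the saturated ring carbon: in this assay, the exchange of 2,3-difluoro-6-methoxyphenyl for 2,4-difluoro-6-methoxyphenyl gives a number 2 percentage points lower from compound 2 to compound 3 (within the scatter), so compound 2 and compound 3 stand level and not every rearrangement on this ring carries through to the maximal response. The large gap remains only against the 3,4-difluoro-2-methoxyphenyl group, with a number 86 percentage points lower from compound 1 to compound 3 (beyond the scatter) alongside the earlier a number 84 percentage points lower from compound 1 to compound 2 (beyond the scatter), and within these three compounds that group alone stands apart. No measurement at hand accounts for why one exchange leaves the response level while the other two separate it so widely.

From the compounds shown here alone, the three compounds differ only in the arrangement of two fluorines and one methoxy on the phenyl group, so it stays open whether the level reading of compound 2 and compound 3 would hold with ethoxy in place of methoxy or with chlorine in place of either fluorine. The cyclopropylmethyl group and the chlorine on the shared core are constant here, and a cyclobutylmethyl or a methyl in those places would test whether the gap to compound 1 persists.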